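Removing the Pyrrolidine from a Phenyl Ester

The compounds below may be only part of what the source reports. "The series", "measured", "known", "first", "only" and "open" are said of these compounds alone.

Among three compounds tested in an ADME assay on microsomes from liver (Rattus norvegicus, strain Sprague-Dawley) for metabolic stability, read by LC-MS, with a stated time of 15 min, tested at 20 uM (a higher number here means that more of the compound is left, a lower number that less of the compound is left), compound 3 `O=C(Oc1ccccc1N1CCCC1)c1coc(-c2ccccc2)n1` stands lowest, giving 11.2%. Compound 2 `Cc1cc(C)c(OC(=O)c2coc(-c3ccccc3)n2)c(C)c1` gives 22%, and compound 1 `CCc1ccccc1COC(=O)c1c(C)nc2cc(C)ccn12` gives 37%; both steps from compound 3 to these two lie beyond the usual scatter, so compound 3 is the least stable of the three. Compound 4 `O=C(Oc1ccccc1)c1coc(-c2ccccc2)n1` has not yet been measured in this assay. It differs from compound 3 in a single place: hydrogen in place of pyrrolidin-1-yl on an aromatic carbon. Going by the values given here, no measured pair shows this change, so its size is open. The step of a number 10.8 percentage points higher from compound 3 to compound 4 (beyond the scatter) is expected to run upward, modestly beyond the scatter. Compound 4 is therefore estimated to give 22%, with a range from 8% to 42%.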

Compound 4, percent of the compound remaining: 0.2%
For compound 4 the middle estimate is 21.8 percentage points above the measured one; measured number outside the range, below it.
By their numbers in this assay, from the lowest: compound 4; then compound 3; then compound 2; then compound 1.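

Hydrogen in place of pyrrolidin-1-yl on an aromatic carbon gives a number 11 percentage points lower from compound 3 to compound 4 (beyond the scatter) in this assay, so at this place the pyrrolidin-1-yl group goes with more of the compound left, not less. This single pair is the only direct view of the change. Nothing at hand explains the step. As far as these compounds go, whether a dimethylamino or methoxy group at the same place would also leave more of the compound than hydrogen stays open. So does whether the step would hold on another core.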